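The compounds below may be only part of what the source reports. "The series", "measured", "known", "first", "only" and "open" are said of these compounds alone.

Series notes

The parent, compound 1 `O=c1c(CSC(=S)N2CCCC2)coc2ccccc12`, in a functional assay on SW480 cells (Homo sapiens) for antiproliferative activity, read by MTT assay, with a stated time of 72 h (on this read-out higher numbers stand for weaker inhibition and lower numbers for stronger inhibition), gives 2300 nM. Two variations on it have been measured. Compound 2 `O=c1c(CSC(=S)N2CCCC2)coc2cc(Cl)ccc12` carries the change (chloro in place of hydrogen on an aromatic carbon); in this assay compound 2 gives 7800 nM, a step of a 3.4-fold higher number from compound 1 to compound 2 (0.53 log units; beyond the scatter). Compound 3 `CC(C)N(C(=S)SCc1coc2ccccc2c1=O)C(C)C` differs from compound 1 by diisopropylamino in place of pyrrolidin-1-yl on a thiocarbonyl carbon; in this assay compound 3 gives 6800 nM, a step of a 3.0-fold higher number from compound 1 to compound 3 (0.47 log units; beyond the scatter). Compound 2 and compound 3 stand within the scatter of each other, so no order between them is claimed.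

Compound 4 `CC(C)N(C(=S)SCc1coc2cc(Cl)ccc2c1=O)C(C)C` is not yet measured. It differs from compound 3 by chloro in place of hydrogen on an aromatic carbon. Among the measured compounds shown here, this is the same change as the one between compound 1 and compound 2, here made on the core of compound 3 rather than the core of compound 1; the two cores differ by diisopropylamino in place of pyrrolidin-1-yl on a thiocarbonyl carbon. The change occurs twice among the compounds shown, and its one measured instance is the step of a 3.4-fold higher number from compound 1 to compound 2 (0.53 log units; beyond the scatter).

For the measured compounds named here, with only one measured instance, the expectation for compound 4 rests on that single step. The step from compound 3 to compound 4 in this assay is expected to be about a 2.9-fold higher number from compound 3 to compound 4 (0.47 log units; beyond the scatter), of the same size as the measured one, because compound 2 gave a 3.4-fold higher number from compound 1 to compound 2 (0.53 log units; beyond the scatter). For compound 4 the estimated value in this assay is 20000 nM, with a range expected from 8000 nM to 50000 nM. Whether the two changes add up in this way is not tested by any compound shown here.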

Compound 4, half-maximal inhibitory concentration: > 25000 nM
Compound 4 ended at the assay's limit; the forecaster's own chance of this, stated with the estimate: 12%; middle value at least 1.2-fold (0.09 log units) away from the limit.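

In this assay compound 4 gives > 25000 nM, which is a limit of the assay and not a number. Carried onto the core of compound 3, chloro in place of hydrogen on an aromatic carbon gives an at least 3.6-fold higher number from compound 3 to compound 4 (0.56 log units; beyond the scatter), so the step runs in the same direction on both cores, and side by side the two steps read: the same change on two cores in this assay, a 3.4-fold higher number (0.53 log units; beyond the scatter) from compound 1 to compound 2 and an at least 3.6-fold higher number (0.56 log units; beyond the scatter) from compound 3 to compound 4; the limit leaves it open whether they differ. The other change, diisopropylamino in place of pyrrolidin-1-yl on a thiocarbonyl carbon, gives an at least 3.2-fold higher number from compound 2 to compound 4 (0.50 log units; beyond the scatter), so the direction again carries from one core to the other, while an equal size is not shown for either change: the same change on two cores in this assay, a 3.0-fold higher number (0.47 log units; beyond the scatter) from compound 1 to compound 3 and an at least 3.2-fold higher number (0.50 log units; beyond the scatter) from compound 2 to compound 4; the limit leaves it open whether they differ.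

From the compounds shown here alone, how far compound 4 lies past its limit stays open, and with it whether the two changes simply add on this series. Also open, going by these compounds, is whether the same direction holds for other groups at the aromatic carbon, such as fluoro, methoxy or a carboxylic acid, or for other amines on the thiocarbonyl carbon, such as morpholine or a dialkylamine with longer chains.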